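Replacing a dioxolane with a sugar on the triazole

The source may hold more compounds than are shown below. What is called first, only, known or untested is meant among the compounds shown, and "the series" means these compounds.

Measured so far in a functional assay on HCT-116 cells (Homo sapiens) for cytotoxicity, read by MTT assay, with a stated time of 72 h; on this read-out lower numbers stand for stronger inhibition and higher numbers for weaker inhibition:
compound 1 `O=C1c2c[n+]([O-])c3ccccc3c2C(=O)c2c1c1ccccc1n2Cc1cn(C[C@@H](O)CO)nn1` gives 190 nM
compound 2 `CC1(C)OCC(Cn2cc(Cn3c4c(c5ccccc53)C(=O)c3c[n+]([O-])c5ccccc5c3C4=O)nn2)O1` gives 70 nM
compound 3 `CC1(C)OC[C@@H](Cn2cc(Cn3c4c(c5ccccc53)C(=O)c3c[n+]([O-])c5ccccc5c3C4=O)nn2)O1` gives 340 nM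

Compound 3 carries the highest number of the three. Its nearest neighbour is compound 1, whose value lies within the scatter of it; compound 2 sits furthest away, beyond the scatter, as the step of a 4.9-fold higher number from compound 2 to compound 3 (0.69 log units; beyond the scatter) shows. The step of a 1.8-fold higher number from compound 1 to compound 3 (0.25 log units; within the scatter) stays within the scatter, and the step of a 2.7-fold lower number from compound 1 to compound 2 (0.43 log units; beyond the scatter) is modest; the difference between compound 2 and compound 3 rests on (the fact that one of compounds 2 and 3 is drawn with a defined configuration and the other without, at the place where they differ), so the two cannot be treated as the same compound.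

Compound 4 `O=C1c2c[n+]([O-])c3ccccc3c2C(=O)c2c1c1ccccc1n2Cc1cn([C@@H]2O[C@H](CO)[C@@H](O)[C@H](O)[C@H]2O)nn1` has not been measured. It differs from compound 3 as follows: 3,4,5-trihydroxy-6-(hydroxymethyl)oxan-2-yl in place of (2,2-dimethyl-1,3-dioxolan-4-yl)methyl on an aromatic nitrogen.

Within the data shown here, no measured step exchanges one of these two groups for the other, so none bears on it directly. The closest guide is the swap between 1,2-dihydroxyethyl and 2,2-dimethyl-1,3-dioxolan-4-yl, which moved the number within the scatter in one direction and modestly in the other. A change of that order, or none beyond the scatter, is the reasonable expectation in this assay.

Compound 4 is therefore estimated at 250 nM, with a range from 80 nM to 800 nM. This estimate corresponds to an expected step of a 1.4-fold lower number from compound 3 to compound 4 (0.13 log units; within the scatter).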

Compound 4, half-maximal inhibitory concentration: 130 nM
Compound 4: the middle estimate sits 1.9-fold (0.28 log units) above what was measured; low and high end bracket the measured number.
By their numbers in this assay, from the lowest: compounds 2, 4, 1 and 3 (each within the scatter of the next, the first and the last beyond it).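

Compounds 1 to 3 only varied a side chain carrying a diol or its 2,2-dimethyl-1,3-dioxolan-4-yl form, whereas compound 4 shows that an aromatic nitrogen of the five-membered aromatic ring also tolerates the much larger 3,4,5-trihydroxy-6-(hydroxymethyl)oxan-2-yl group without losing activity in this assay. Against the defined dioxolane the sugar gives a modest gain, a 2.6-fold lower number from compound 3 to compound 4 (0.42 log units; beyond the scatter), while a 1.9-fold higher number from compound 2 to compound 4 (0.27 log units; within the scatter) and a 1.5-fold lower number from compound 1 to compound 4 (0.16 log units; within the scatter) both stay within the scatter, so compound 4 cannot be ranked against compound 1 or compound 2. The same sugar therefore looks better or merely equal depending on which dioxolane compound serves as the reference, because of one unresolved point: the fact that one of compounds 2 and 3 is drawn with a defined configuration and the other without, at the place where they differ.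

The compounds shown leave open whether the hydroxyl groups or the six-membered ring itself carry this result, which a plain oxan-2-yl group at the same nitrogen would help to separate. They also leave open whether this nitrogen accepts a charged end group, such as a 2-aminoethyl chain or a carboxylic acid on a short chain, as readily as it accepts the sugar.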